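Replacing the furan-2-yl group of compound 3

This account rests on a few compounds, and the source may have more. Where it says the series, first, only, none or still open, it means among the compounds named here.

Within the data shown here, compound 3 `CC(C)(C)n1ncc(OCc2nnc(-c3ccco3)o2)c(Cl)c1=O` is the only member of the series without a number: in a functional assay on the whole organism for inhibition, with Mythimna separata as the target, with a stated time of 5 days (on this read-out higher numbers stand for an effect only at larger amounts of compound and lower numbers for an effect already at smaller amounts), compound 3 gives > 299000 nM, which is a limit of the assay (the limit of > 299000 nM in this assay, at which 1 of the 3 values shown sits). Compound 4 `CC(C)(C)n1ncc(OCc2nnc(-c3cc(F)c(Cl)cc3Cl)o2)c(Cl)c1=O` carries the change (2,4-dichloro-5-fluorophenyl in place of furan-2-yl on an aromatic carbon). Among the measured compounds shown here, two measured steps bear on it, both running the other way, from a substituted phenyl group to furan-2-yl: compound 1 `CC(C)(C)n1ncc(OCc2nnc(-c3ccc(Br)cc3)o2)c(Cl)c1=O` gives 21400 nM in this assay, and an at least 13-fold higher number from compound 1 to compound 3 (1.14 log units; beyond the scatter); compound 2 `CC(C)(C)n1ncc(OCc2nnc(-c3ccc(Cl)cc3)o2)c(Cl)c1=O` gives 1900 nM in this assay, and an at least 150-fold higher number from compound 2 to compound 3 (2.19 log units; beyond the scatter). Between 4-bromophenyl and 4-chlorophenyl, an 11-fold lower number from compound 1 to compound 2 (1.05 log units; beyond the scatter). Returning from furan-2-yl to a chlorinated phenyl group is therefore expected to bring a large lower number, an at least 59-fold lower number from compound 3 to compound 4 (1.77 log units; beyond the scatter). Compound 4 is expected to give about 5000 nM in this assay, within 800 nM to 40000 nM.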

Compound 4, half-maximal effective concentration: 23100 nM
Compound 4: middle estimate off by 4.6-fold (0.66 log units), on the low side; the measured number falls inside the stated range.
By their numbers in this assay, from the lowest: compound 2; then compounds 1 and 4 (each within the scatter of the next). At a limit, above all of these: compound 3.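

Compound 3 stands at a limit of the assay, not at a number: the limit of > 299000 nM in this assay, at which 1 of the 4 values shown sits.

In this assay, 2,4-dichloro-5-fluorophenyl gives a real number at this position, with an at least 12-fold lower number from compound 3 to compound 4 (1.11 log units; beyond the scatter). More halogen on the phenyl ring does not carry the result further: 2,4-dichloro-5-fluorophenyl in place of 4-chlorophenyl gives a 12-fold higher number from compound 2 to compound 4 (1.08 log units; beyond the scatter), while in place of 4-bromophenyl it gives a 1.1-fold higher number from compound 1 to compound 4 (0.03 log units; within the scatter).

Which of the three halogens of the 2,4-dichloro-5-fluorophenyl group accounts for the gap to 4-chlorophenyl stays open. So does the outcome with a 4-methoxyphenyl or 4-aminophenyl group at this position.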